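The source may hold more compounds than are shown below. What is called first, only, known or untested is meant among the compounds shown, and "the series" means these compounds.

Compound 1 `COc1cccc(CNCCCNc2ccnc3cc(Oc4ccccc4)ccc23)c1O` stands second highest of the three numbers in an ADME assay on HepG2 cells (Homo sapiens) for cytotoxicity, read by luminescence, CellTiter-Glo and ATP content, with a stated time of 72 h (a lower number here means that less compound is needed, a higher number that more compound is needed for the effect), where compound 1 gives 6800 nM. Its nearest neighbour is compound 3 `COc1ccccc1Oc1ccc2c(NCCCNCc3ccco3)ccnc2c1`, which gives 6500 nM, a gap within the scatter; furthest lies compound 2 `c1ccc(Oc2ccc3c(NCCCNCc4ccco4)ccnc3c2)cc1`, which gives 15200 nM, the step being a 2.2-fold higher number from compound 1 to compound 2 (0.35 log units; beyond the scatter). Compound 4 `COc1ccc(Oc2ccc3c(NCCCNCc4cccc(OC)c4O)ccnc3c2)cc1` differs from compound 1 by methoxy in place of hydrogen on an aromatic carbon. Among the measured compounds shown here, only one measured step is the same kind of change, a 2.3-fold lower number from compound 2 to compound 3 (0.37 log units; beyond the scatter), modest and lowering, though it sits on another carbon of the phenoxy ring and in a chain bearing furan-2-yl. The chemist therefore expects for compound 4 a lowering that is modest or none beyond the scatter, namely a 1.4-fold lower number from compound 1 to compound 4 (0.13 log units; within the scatter). The estimate for compound 4 is 5000 nM, within 2000 nM to 14000 nM.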

Compound 4, half-maximal effective concentration: 5500 nM
Estimate against measurement, compound 4: 1.1-fold (0.04 log units) below, within the range that was stated.
By their numbers in this assay, from the lowest: compounds 4, 3 and 1 (each within the scatter of the next); then compound 2.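

In this assay, methoxy para to a large group, which turns phenoxy into 4-methoxyphenoxy, gives a 1.2-fold lower number from compound 1 to compound 4 (0.09 log units; within the scatter), so at this carbon the change stays within the scatter. The earlier compounds showed the change only at another carbon of the phenoxy ring, in a chain bearing furan-2-yl, and the two steps cannot be told apart: the same change on two cores in this assay, a 2.3-fold lower number (0.37 log units; beyond the scatter) from compound 2 to compound 3 and a 1.2-fold lower number (0.09 log units; within the scatter) from compound 1 to compound 4, 1.9-fold (0.28 log units) apart, within the scatter of two such steps

The compounds shown leave open whether an amine, a carboxylic acid or a longer ether such as ethoxy at this carbon would move the number beyond the scatter. They also leave open how methoxy at this carbon reads with the furan-2-yl chain.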